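The compounds below may be only part of what the source reports. "The series", "measured", "known", "first", "only" and "open" are said of these compounds alone.

Measured so far in a functional assay on Hep 3B2 cells (Homo sapiens) for antiproliferative activity, read by MTT assay, with a stated time of 24 h, tested at 0.41 ug/mL; on this read-out higher numbers stand for a stronger effect at the one concentration tested and lower numbers for a weaker effect:
- compound 1 `Cc1c(C(=O)Nc2c(F)cc(-c3cccc(F)c3)cc2F)nc2ccc(F)cc2c1O`: 4.85%
- compound 2 `Cc1c(C(=O)Nc2c(F)cc(-c3cccc(F)c3)cc2F)nc2ccc(F)cc2c1C(=O)O`: 1.06%

Compound 2 holds the lowest of the two numbers; its nearest neighbour is compound 1, and the gap between them, a number 3.8 percentage points lower from compound 1 to compound 2 (within the scatter), lies within the scatter. The pair therefore shows no difference that can be read as real, and both compounds sit near the bottom of the scale in this assay.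

Compound 3 `Cc1c(C(=O)Nc2c(F)cc(-c3cccc(F)c3)cc2F)nc2ccc(C(F)(F)F)cc2c1C(=O)O` is not yet measured. It differs from compound 2 by trifluoromethyl in place of fluoro on an aromatic carbon. Among the measured compounds shown here, no measured step among the compounds here touches this change: the one step on hand, the swap of carboxy for hydroxy between compound 1 and compound 2, concerns a different position and a different group, and it was itself within the scatter. There is thus no measured basis for expecting movement in this assay in either direction beyond the scatter.

The estimate for compound 3 is accordingly placed close to compound 2, at 4% with a range from -6% to 18%, which corresponds to an expected step of a number 2.9 percentage points higher from compound 2 to compound 3 (within the scatter).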

Compound 3, a percentage reported as inhibition, at one concentration (the size of the read-out at that concentration, not a potency): 6.42%
The estimate for compound 3 lay 2.4 percentage points below the measured number; the measured number falls inside the stated range.
By their numbers in this assay, from the lowest: compounds 2, 1 and 3 (each within the scatter of the next).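

In this assay, the exchange at this position, trifluoromethyl in place of fluoro on an aromatic carbon that is meta to a fused ring and para to a fused ring, gives a number 5.4 percentage points higher from compound 2 to compound 3 (within the scatter), so a group of 4 heavy atoms in place of 1 produces no difference that can be read as real. Among the compounds shown here, this is the first reading at this position, and with the carboxy group held in place, the read-out for compound 3, 6.42%, cannot be separated from that of compound 2, 1.06%. No measurement shown here bears on why the exchange leaves the read-out within the scatter.

Still open, from the compounds shown here alone, is whether an amine, a methoxy group or a nitrile at this position, or a plain hydrogen there, would give a number beyond the scatter, and whether trifluoromethyl gives the same reading with hydroxy in place of carboxy on the shared core. With a single tested concentration, the numbers shown also say nothing about potency, and no compound here yet stands apart from the others.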